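Adding a hydroxy group to compound 3

The compounds below may be only part of what the source reports. "The series", "measured", "known", "first", "only" and "open" are said of these compounds alone.

In a functional assay on A2780 cells (Homo sapiens) for antiproliferative activity, read by sulforhodamine B assay, with a stated time of 48 h (on this read-out higher numbers stand for weaker inhibition and lower numbers for stronger inhibition), compound 3 (`COc1ccc(/C=C/C(=O)c2ccccc2-c2cccc(F)c2)cc1`) gives 160 nM, the middle of three numbers. Compound 1 (`COc1ccc(/C=C/C(=O)c2ccccc2-c2ccc(F)cc2)cc1`) gives 170 nM, and a 1.1-fold lower number from compound 1 to compound 3 (0.03 log units; within the scatter) places the two together. Compound 2 (`COc1ccc(/C=C/C(=O)c2ccccc2-c2ccc(F)cc2)cc1O`) gives 27 nM, clearly lower than either. Compound 4 (`COc1ccc(/C=C/C(=O)c2ccccc2-c2cccc(F)c2)cc1O`) differs from compound 3 by one change, hydroxy in place of hydrogen on an aromatic carbon, ortho to a methoxy group. The same change was measured once, as a 6.3-fold lower number from compound 1 to compound 2 (0.80 log units; beyond the scatter). Going by these compounds, the 3-fluorophenyl and 4-fluorophenyl compounds read alike, so a step of similar size and direction is expected, though it is untested with 3-fluorophenyl. The expected change is a 6.2-fold lower number from compound 3 to compound 4 (0.79 log units; beyond the scatter). For compound 4 the estimated value is 26 nM, with an expected range from 10 nM to 70 nM.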

Compound 4, half-maximal inhibitory concentration: 13 nM
Compound 4: middle estimate off by 2.0-fold (0.30 log units), on the high side; low and high end bracket the measured number.
By their numbers in this assay, from the lowest: compound 4; then compound 2; then compounds 3 and 1 (each within the scatter of the next).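

Hydroxy in place of hydrogen, ortho to a methoxy group, now lowers the number with 3-fluorophenyl as well as with 4-fluorophenyl, as a 12-fold lower number from compound 3 to compound 4 (1.09 log units; beyond the scatter), and the two steps agree in direction and size: the same change on two cores in this assay, a 6.3-fold lower number (0.80 log units; beyond the scatter) from compound 1 to compound 2 and a 12-fold lower number (1.09 log units; beyond the scatter) from compound 3 to compound 4, 2.0-fold (0.29 log units) apart, within the scatter of two such steps. With the hydroxy group present, 3-fluorophenyl in place of 4-fluorophenyl gives a 2.1-fold lower number from compound 2 to compound 4 (0.32 log units; beyond the scatter), although the same swap separated nothing without it, and the gap between these two steps stays within the scatter: the same change on two cores in this assay, a 1.1-fold lower number (0.03 log units; within the scatter) from compound 1 to compound 3 and a 2.1-fold lower number (0.32 log units; beyond the scatter) from compound 2 to compound 4, 2.0-fold (0.29 log units) apart, within the scatter of two such steps. The compounds shown leave open whether an amine or an ethoxy group at this place would lower the number as hydroxy does.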